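A Pyridin-2-yl to 4-Chlorophenyl Exchange at the Assay Limit

A few compounds are considered here, and "the series" means these few. Any claim that something is new, unique, unknown or untested is made for them only; others in the source may bear on it.

Of the compounds shown here, three have been measured in a functional assay on HL-60 cells (Homo sapiens) for cytotoxicity, read by MTT assay, with a stated time of 4 days; on this read-out higher numbers stand for weaker inhibition and lower numbers for stronger inhibition. Compound 1 `C=C1C[C@]23C[C@@]1(O)CC[C@H]2c1ccc(OS(=O)(=O)c2ccc(C)cc2)c(C)c1[C@@H]3Cn1cc(-c2ccc(OC)cc2)nn1` gives > 20000 nM in this assay, which is a limit of the assay and not a number. Compound 2 `C=C1C[C@]23C[C@@]1(O)CC[C@H]2c1cc(Br)c(O)c(C)c1[C@@H]3Cn1cc(-c2ccc(C)cc2)nn1` gives > 20000 nM in this assay, again a limit. Compound 3 `C=C1C[C@]23C[C@@]1(O)CC[C@H]2c1cc(Br)c(O)c(C)c1[C@@H]3Cn1cc(-c2ccccn2)nn1` gives > 20000 nM in this assay, also a limit. For the measured compounds named here, compound 3 therefore stands where both other compounds stand, since every value shown sits at the same limit (the limit of > 20000 nM in this assay, at which 3 of the 3 values shown sit), and no compound can be separated from another.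

Going by the values given here, the only step between measured compounds that differ in a single place, a step that the two limits leave unreadable from compound 2 to compound 3, cannot be read, because both of its ends are limits.

Compound 4 `C=C1C[C@]23C[C@@]1(O)CC[C@H]2c1cc(Br)c(O)c(C)c1[C@@H]3Cn1cc(-c2ccc(Cl)cc2)nn1` has not yet been measured. It differs from compound 3 by the change 4-chlorophenyl in place of pyridin-2-yl on an aromatic carbon on an aromatic carbon of a five-membered aromatic ring with three nitrogen, next to the ring nitrogen. The one measured step shares the leaving pyridin-2-yl but gives no size and no direction, so no step beyond the scatter can be expected in this assay on the basis of the numbers shown. Compound 4 is therefore expected to give about 30000 nM, estimated between 15000 nM and 80000 nM, most likely again as a limit. The expected step that the limit leaves unreadable from compound 3 to compound 4 is thus estimated to lie within the scatter.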

Compound 4, half-maximal inhibitory concentration: 5590 nM
Estimate against measurement, compound 4: 5.4-fold (0.73 log units) above; measured number below the stated range.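

In this assay, the exchange of pyridin-2-yl for 4-chlorophenyl on an aromatic carbon of the five-membered aromatic ring with 3 nitrogen gives an at least 3.5-fold lower number from compound 3 to compound 4 (0.55 log units; beyond the scatter), and this gives the series its first readable steps. Chloro in place of methyl on an aromatic carbon gives an at least 3.5-fold lower number from compound 2 to compound 4 (0.55 log units; beyond the scatter), so the 4-chlorophenyl group also separates from the 4-methylphenyl group on the same core. The group at this position can therefore move the number in this assay, which the earlier compounds could not show, and their one step between compounds differing in a single place cannot be read: the limit of > 20000 nM in this assay, at which 3 of the 4 values shown sit.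

From the compounds shown here alone, both readable steps start from a limit and end at compound 4, so their full size remains open, and they show no trend across the aryl groups beyond this single value. Going by these compounds, whether the effect belongs to chloro itself also stays open, as does what a 4-fluorophenyl, a 4-aminophenyl or a 4-carboxyphenyl group would give at this position on the same core.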